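Chloro Substitution on Two Isomeric Benzyl Purine Cores

A few compounds are considered here, and "the series" means these few. Any claim that something is new, unique, unknown or untested is made for them only; others in the source may bear on it.

Compound 1 `ClCc1cccc(Cn2cnc3ncnc(Cl)c32)c1` and compound 2 `ClCc1ccccc1Cn1cnc2ncnc(Cl)c21` contain the same atoms joined differently; the difference between the two cores is not broken down here. In a functional assay on RXF 393 cells (Homo sapiens) for cytotoxicity, read by sulforhodamine B assay, with a stated time of 48 h (on this read-out lower numbers stand for higher toxicity in this test and higher numbers for lower toxicity in this test), compound 1 gives 47900 nM. In this assay compound 2 gives only a limit, > 100000 nM. Compound 3 `ClCc1cccc(Cn2cnc3nc(Cl)nc(Cl)c32)c1` carries one change from compound 1, (chloro in place of hydrogen on an aromatic carbon), and in this assay compound 3 gives 5120 nM, which is a 9.4-fold lower number from compound 1 to compound 3 (0.97 log units; beyond the scatter). Compound 4 `ClCc1ccccc1Cn1cnc2nc(Cl)nc(Cl)c21` is not yet measured; it carries the same change from compound 2, (chloro in place of hydrogen on an aromatic carbon). For compound 4 a step of similar size is expected, an at least 4.0-fold lower number from compound 2 to compound 4 (0.60 log units; beyond the scatter), resting on the measured step of a 9.4-fold lower number from compound 1 to compound 3 (0.97 log units; beyond the scatter). Compound 4 is therefore estimated at 25000 nM, within 8000 nM to 100000 nM, though because the limit of > 100000 nM in this assay, at which 1 of the 3 values shown sits, holds one of the three values, compound 4 may again give only a limit.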

Compound 4, concentration lethal to 50% of the cells: 6450 nM
Compound 4: middle estimate off by 3.9-fold (0.59 log units), on the high side; measured number below the stated range.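

On the second core the chloro in place of hydrogen again lowers the number in this assay, giving an at least 15-fold lower number from compound 2 to compound 4 (1.19 log units; beyond the scatter). Compound 2 gives only a limit here, > 100000 nM. The change therefore acts in the same direction on both cores, but these two pairs do not show that its size carries over unchanged from one core to the other: the same change on two cores in this assay, a 9.4-fold lower number (0.97 log units; beyond the scatter) from compound 1 to compound 3 and an at least 15-fold lower number (1.19 log units; beyond the scatter) from compound 2 to compound 4; the limit leaves it open whether they differ

Among the compounds shown, only chloro takes the place of that hydrogen, so it remains open whether an amine, a methoxy group or a longer chain there would give a similar step. Going by these compounds, whether the chloro step holds on any core beyond these two also remains open.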